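The source may report more compounds than this note shows. Statements on the series, on what has been measured and on what is new or still open speak of the compounds shown alone.

Compound 2 `CN(C)C1(Cc2ccccc2)CCN(c2cc(C(F)(F)F)ccc2CNC(=O)Nc2cccc3ccc(O)cc23)CC1` sits at the low end of the series: in an assay on CHO cells for displacement of a labelled ligand from transient receptor potential cation channel subfamily V member 1 (Homo sapiens), read by scintillation counting, with a stated time of 60 min (on this read-out lower numbers stand for stronger inhibition and higher numbers for weaker inhibition), compound 2 gives 0.46 nM. Compound 1 `CN(C)C1(Cc2ccccc2)CCN(c2cc(C(F)(F)F)ccc2CNC(=O)Nc2ccc(CNS(C)(=O)=O)c(F)c2)CC1` gives 16.4 nM, and compound 3 `CN(C)C1(Cc2ccccc2)CCN(c2cc(C(F)(F)F)ccc2CNC(=O)Nc2cccc3c(=O)[nH]ccc23)CC1` gives 111 nM. Going by the values given here, the only measured step that bears on the question is the one on the amide-type nitrogen, which reads a 240-fold higher number from compound 2 to compound 3 (2.38 log units; beyond the scatter). Compound 4 `CN(C)C1(Cc2ccccc2)CCN(c2cc(C(F)(F)F)ccc2CNC(=O)Nc2ccc3cnccc3c2)CC1` carries the change (isoquinolin-6-yl in place of 7-hydroxynaphthalen-1-yl on an amide-type nitrogen); the hydroxyl donor leaves and the ring nitrogen acceptor enters. The change from compound 2 to compound 3 was large, and the present change also removes the hydroxyl, so a weakening is expected, though smaller than that step. The expected step is an 11-fold higher number from compound 2 to compound 4 (1.04 log units; beyond the scatter). Compound 4 is estimated at 5 nM, with a range of 1 nM to 30 nM.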

Compound 4, inhibition constant: 62 nM
Estimate against measurement, compound 4: 12-fold (1.09 log units) below, and the stated range ends below it.
By their numbers in this assay, from the lowest: compound 2; then compound 1; then compounds 4 and 3 (each within the scatter of the next).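

At this amide-type nitrogen, the bicyclic aromatic group alone does not hold the low number: isoquinolin-6-yl in place of 7-hydroxynaphthalen-1-yl gives a 130-fold higher number from compound 2 to compound 4 (2.13 log units; beyond the scatter) in this assay. A second group with a ring hetero atom gives no separation from the first, with a 1.8-fold lower number from compound 3 to compound 4 (0.25 log units; within the scatter), so compound 2 remains apart from both. No evidence here bears on the reason for the loss.

From the compounds shown here alone, the change removes the hydroxyl and adds the ring nitrogen together, so their separate contributions remain open. Naphthalen-1-yl or 7-aminonaphthalen-1-yl on the same nitrogen would address that question.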